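Urea amide swap measured; ethoxy for chloro awaits a number

The compounds below may be only part of what the source reports. "The series", "measured", "known", "first", "only" and "open" are said of these compounds alone.

The series rests on a shared core carrying a methyl-substituted pyrazole. Compound 1 `Cc1cc(CNC(=O)c2cc(Cl)nc(Cl)c2)ncc1-c1cn(C)nc1C` is a picolinamide. In a functional assay on CHO cells for agonist activity at sphingosine 1-phosphate receptor 2 (Homo sapiens), read by fluorescence and calcium flux, with a stated time of 3 min (a higher number here means a weaker inhibitor, a lower number a stronger inhibitor), compound 1 gives a limit of the assay, < 1700 nM. Compound 2 `Cc1cc(CNC(=O)Nc2cc(Cl)nc(Cl)c2)ncc1-c1cn(C)nc1C` replaces the amide by a urea. In this assay compound 2 gives 3500 nM, the only plain number shown. The other value, that of compound 1, is a limit, as recorded in the limit of < 1700 nM in this assay, at which 1 of the 2 values shown sits. On these data alone, the step of an at least 2.0-fold higher number from compound 1 to compound 2 (0.31 log units; beyond the scatter) is a change at the carbonyl carbon and is beyond the scatter, though its exact size stays open.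

Compound 3 `CCOc1cc(NC(=O)NCc2cc(C)c(-c3cn(C)nc3C)cn2)cc(Cl)n1` keeps the urea of compound 2 and differs only on the dichloropyridine: ethoxy in place of chloro on an aromatic carbon. Within the data shown here, the one measured step concerns the carbonyl linkage and leaves the pyridine substituents untouched, so no measured step bears on this exchange. Compound 3 is therefore expected to stay close to compound 2, with a step of no change at the digits printed from compound 2 to compound 3 (within the scatter) that need not exceed the scatter in either direction. The estimate for compound 3 in this assay is 3500 nM, within a range from 1000 nM to 12000 nM.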

Compound 3, half-maximal inhibitory concentration: 4700 nM
The estimate for compound 3 lay 1.3-fold (0.13 log units) below the measured number; measured number inside the range.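

In this assay, the exchange of chloro for ethoxy gives a 1.3-fold higher number from compound 2 to compound 3 (0.13 log units; within the scatter), so this change on an aromatic carbon next to the ring nitrogen does not move the number beyond the scatter. Among these compounds, the earlier compounds differed only at the carbonyl linkage, so this is the first reading on a substituent of the pyridine ring, and it shows that this position accepts ethoxy, with its added oxygen and hydrogen-bond acceptor, in place of chloro without a change that can be told from the scatter. None of the evidence shown gives a reason for this outcome.

What the compounds shown leave open is whether an amine, a carboxylic acid or a longer alkoxy chain on this carbon would keep the number in the same region, and whether the remaining chloro group could be exchanged in the same way. Also open, on these data alone, is how ethoxy would read with the amide linkage of compound 1, whose value is a limit of the assay and not a number.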